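A few compounds are considered here, and "the series" means these few. Any claim that something is new, unique, unknown or untested is made for them only; others in the source may bear on it.

Working notes on the series.

In an assay on isolated protein for binding affinity to adenosine receptor A1 (Bos taurus) (on this read-out lower numbers stand for stronger inhibition and higher numbers for weaker inhibition), compound 1 `c1ccc(Cn2nnc3c(NC4CCCC4)nc(-c4ccccc4)nc32)cc1` gives 11000000 nM. Going by the values given here, it stands second highest of the three numbers measured so far. The nearest value is that of compound 2 `CC(O)CNc1nc(-c2ccccc2)nc2c1nnn2Cc1ccccc1F`, which gives 4800000 nM in this assay; the furthest is that of compound 3 `OCCNc1nc(-c2ccccc2)nc2c1nnn2Cc1ccccc1F`, which gives 54000000 nM. Among the compounds with values here, the one step measured is an 11-fold higher number from compound 2 to compound 3 (1.05 log units; beyond the scatter).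

Compound 4 `CCCCNc1nc(-c2ccccc2)nc2c1nnn2Cc1ccccc1` is the next compound for this assay. Compound 4 differs from compound 1 by butyl in place of cyclopentyl on a nitrogen on an aromatic ring. Within the data shown here, none of the measured steps covers this exchange: the step from compound 2 to compound 3 alters the group on the ring nitrogen in another way, and it is the only step at hand, so it serves at most as a sign that the group on this nitrogen can move the number appreciably. Among the measured compounds shown here, with no direct precedent, the expectation for compound 4 is a step of a 1.4-fold higher number from compound 1 to compound 4 (0.13 log units; within the scatter), within the scatter. The estimate for compound 4 in this assay is 15000000 nM, expected to lie between 4000000 nM and 60000000 nM.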

Compound 4, inhibition constant: 11000000 nM
Beside the measured number, compound 4's estimate is 1.4-fold (0.13 log units) above it; measured number inside the range.
By their numbers in this assay, from the lowest: compound 2; then compounds 1 and 4 (each within the scatter of the next); then compound 3.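

In this assay, butyl in place of cyclopentyl on a nitrogen on an aromatic ring gives no change at the digits printed from compound 1 to compound 4 (within the scatter) in this series. At this place, then, the five-membered non-aromatic ring of carbon only is not required to keep the number, and the open-chain butyl serves alike, even though the earlier step, an 11-fold higher number from compound 2 to compound 3 (1.05 log units; beyond the scatter), showed that a change in the group on this nitrogen can move the number well beyond the scatter. No supporting data on hand offer an explanation for this result.

Going by these compounds, whether a longer chain such as hexyl, or a butyl chain ending in an amine or a carboxylic acid, would hold the number at this nitrogen stays open. Equally open, on these data alone, is whether cyclohexyl in place of cyclopentyl would leave it unchanged.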